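This account rests on a few compounds, and the source may have more. Where it says the series, first, only, none or still open, it means among the compounds named here.

Of the compounds shown here, three built on one shared core have been measured in a functional assay on HepG2 cells (Homo sapiens) for antiproliferative activity, read by MTT assay, with a stated time of 24 h; a lower number here means a stronger inhibitor, a higher number a weaker inhibitor. Compound 1 `COc1cc(OC)c(-c2coc3cc(OCc4ccccc4F)ccc3c2=O)cc1OC` gives 1280 nM. Compound 2 `COc1cc(OC)c(-c2coc3cc(OCc4ccccc4C)ccc3c2=O)cc1OC` gives 1860 nM, and compound 3 `COc1cc(OC)c(-c2coc3cc(OCc4ccc(Cl)cc4)ccc3c2=O)cc1OC` gives 940 nM. Among these three numbers compound 1 stands second highest; its nearest neighbour is compound 3 and its furthest is compound 2, yet both gaps lie within the scatter, so no order among the three can be read from them.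

Compound 4 `COc1cc(OC)c(-c2coc3cc(OCc4ccccc4Br)ccc3c2=O)cc1OC` has not yet been measured. It differs from compound 1 by bromo in place of fluoro on an aromatic carbon. The measured step that bears most directly on this change is the exchange made at the same aromatic carbon, a 1.5-fold higher number from compound 1 to compound 2 (0.16 log units; within the scatter), which stayed within the scatter. The two steps that exchange the whole benzyl group, a 1.4-fold lower number from compound 1 to compound 3 (0.13 log units; within the scatter) and a 2.0-fold lower number from compound 2 to compound 3 (0.30 log units; within the scatter), also stayed within the scatter. Among the compounds with values here, nothing among the measured compounds therefore points to a shift beyond the scatter when bromo takes the place of fluoro here, and for compound 4 a number close to that of compound 1 is expected, that is a 1.0-fold higher number from compound 1 to compound 4 (0.01 log units; within the scatter). Compound 4 is accordingly estimated at 1300 nM, with a range from 600 nM to 2800 nM.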

Compound 4, half-maximal inhibitory concentration: 2180 nM
For compound 4 the middle estimate is 1.7-fold (0.22 log units) below the measured one; measured number inside the range.
By their numbers in this assay, from the lowest: compounds 3, 1, 2 and 4 (each within the scatter of the next, the first and the last beyond it).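

In this assay, the aromatic carbon that carries the halogen now has three groups to compare, and the exchanges involving bromo stay within the scatter: bromo for fluoro (a 1.7-fold higher number from compound 1 to compound 4 (0.23 log units; within the scatter)) and bromo for methyl (a 1.2-fold higher number from compound 2 to compound 4 (0.07 log units; within the scatter)), so fluoro, methyl and bromo at this place cannot be ordered. Within the data shown here, what the earlier compounds did not show is a gap beyond the scatter, which appears in the exchange of the 4-chlorophenyl group for the 2-bromophenyl group (a 2.3-fold higher number from compound 3 to compound 4 (0.37 log units; beyond the scatter)), a modest step in which both the halogen and its place on the ring differ. No measurement is available that would account for this gap.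

On these data alone, whether the gap follows the halogen or its place on the ring stays open, a question on which 4-bromophenyl or 2-chlorophenyl groups would bear. Also open, as far as these compounds go, is whether an amine or a carboxylic acid on this aromatic carbon would stay within the scatter, as fluoro, methyl and bromo do.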